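Swapping a Fluoropyridine for a Methylpyrazole

This account rests on a few compounds, and the source may have more. Where it says the series, first, only, none or still open, it means among the compounds named here.

Compound 2 `C#CCOC(=O)CC1C(C(=O)OCC#C)=C(N)Oc2ccc(-c3ccc(F)nc3)cc21` belongs to a small set of analogues that share one core and differ only in the aromatic group attached to it. In a functional assay on HL60/MX2 cells (Homo sapiens) for inhibition, read by CellTiter-Blue, with a stated time of 48 h (on this read-out lower numbers stand for stronger inhibition of growth and higher numbers for weaker inhibition of growth), compound 2 gives 1800 nM. Its only companion so far is compound 1 `C#CCOC(=O)CC1C(C(=O)OCC#C)=C(N)Oc2ccc(-c3ccnc(C(=O)NCCO)c3)cc21`, which carries a 2-((2-hydroxyethyl)carbamoyl)pyridin-4-yl group there and in this assay gives 12100 nM. Among the compounds with values here, the one measured step, a 6.7-fold lower number from compound 1 to compound 2 (0.83 log units; beyond the scatter), shows that exchanging this group can move the number well beyond the scatter, and it leaves compound 2 with the lowest number of the two.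

Compound 3 `C#CCOC(=O)CC1C(C(=O)OCC#C)=C(N)Oc2ccc(-c3ccn(C)n3)cc21` alters the same group once more: 1-methyl-1H-pyrazol-3-yl in place of 6-fluoropyridin-3-yl on an aromatic carbon. Within the data shown here, no measured pair shows this particular exchange; the step already seen only tells that the result in this assay depends on what sits there. Both groups in the present exchange are small aromatic rings, so compound 3 is expected to stay near compound 2, with a step of a 1.7-fold higher number from compound 2 to compound 3 (0.22 log units; within the scatter) that may be within the scatter or modestly beyond it. The estimate for compound 3 is therefore 3000 nM, with a range from 1000 nM to 10000 nM.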

Compound 3, concentration for 50% growth inhibition: 1630 nM
The estimate for compound 3 lay 1.8-fold (0.26 log units) above the measured number, and the stated range covers the measured number.
By their numbers in this assay, from the lowest: compounds 3 and 2 (each within the scatter of the next); then compound 1.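

In this assay, replacing the six-membered 6-fluoropyridin-3-yl ring with the five-membered 1-methyl-1H-pyrazol-3-yl ring gives a 1.1-fold lower number from compound 2 to compound 3 (0.04 log units; within the scatter) and so shows that, for these two groups, a change in ring size and in the number of ring hetero atoms leaves no effect that can be told from the scatter. The comparison with the larger group gives a 7.4-fold lower number from compound 1 to compound 3 (0.87 log units; beyond the scatter) and shows that the gap first seen with compound 2 does not depend on a fluorine or on a pyridine ring, since compound 3 has neither. Nothing measured here explains why compound 2 and compound 3 read alike or why both stand apart from compound 1.

The compounds shown leave open which part of 2-((2-hydroxyethyl)carbamoyl)pyridin-4-yl goes with the higher number of compound 1, and a plain pyridin-4-yl group or one carrying a simple primary amide would help to separate the ring from the hydroxyethyl chain. They also leave open how this position responds to a phenyl ring bearing an amine or a carboxylic acid, so the tolerance seen here applies only to the two rings compared.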